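Urea to amide switch on the shared core

A few compounds are considered here, and "the series" means these few. Any claim that something is new, unique, unknown or untested is made for them only; others in the source may bear on it.

Measured in a functional assay on UACC-62 cells (Homo sapiens) for inhibition, read by sulforhodamine B assay, with a stated time of 48 h; a higher number here means a weaker inhibitor, a lower number a stronger inhibitor:
compound 1 `O=C(Nc1cccc(-n2cc(-c3ccncc3)c(-c3cc(O)cc(Cl)c3)n2)c1)Nc1ccc(Cl)c(Cl)c1` gives 1690 nM
compound 2 `COc1cc(Cl)cc(-c2nn(-c3cccc(NC(=O)Nc4cc(C(F)(F)F)cc(C(F)(F)F)c4)c3)cc2-c2ccncc2)c1` gives 360 nM
compound 3 `COc1cc(Cl)cc(-c2nn(-c3cccc(NC(=O)Nc4ccc(Cl)c(Cl)c4)c3)cc2-c2ccncc2)c1` gives 2400 nM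

Compound 3 stands at the highest number of the three. Its nearest neighbour is compound 1, reached by a 1.4-fold higher number from compound 1 to compound 3 (0.15 log units; within the scatter). Compound 2 lies furthest away, and the gap between the values of compound 2 and compound 3 is beyond the scatter.

Compound 4 `COc1cc(Cl)cc(-c2nn(-c3cccc(NC(=O)c4cccc(C(F)(F)F)c4)c3)cc2-c2ccncc2)c1` carries 3-(trifluoromethyl)phenyl in place of (3,4-dichlorophenyl)amino on a carbonyl carbon. No measured step touches this place: the only step shown concerns an oxygen substituent elsewhere on the core. No size or direction can therefore be read from the series for this assay, and the expectation is a number close to that of compound 3, with wide uncertainty, a 1.3-fold higher number from compound 3 to compound 4 (0.10 log units; within the scatter). Compound 4 is estimated at 3000 nM, within 800 nM to 12000 nM.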

Compound 4, half-maximal inhibitory concentration: 8040 nM
Estimate against measurement, compound 4: 2.7-fold (0.43 log units) below; measured number inside the range.
By their numbers in this assay, from the lowest: compound 2; then compounds 1 and 3 (each within the scatter of the next); then compound 4.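

In this assay, 3-(trifluoromethyl)phenyl in place of (3,4-dichlorophenyl)amino on the carbonyl carbon gives a 3.4-fold higher number from compound 3 to compound 4 (0.53 log units; beyond the scatter) and so a weaker inhibitor. This place therefore responds to change beyond the scatter, whereas the step on the oxygen substituent did not. The change removes the urea nitrogen and its hydrogen-bond donor and alters the ring substituents together, and no evidence bears on the cause.

Which part of the change carries the step remains open. A 3,4-dichlorophenyl or a (3-(trifluoromethyl)phenyl)amino on the same carbonyl carbon would separate the two.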